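Trimethoxyphenyl on the imidazolone ring: expected potency

The source may report more compounds than this note shows. Statements on the series, on what has been measured and on what is new or still open speak of the compounds shown alone.

Working notes. Compound 1 `COc1ccc(-c2cn(-c3cccc(C(=O)/C=C/c4cc(OC)c(OC)c(OC)c4)c3)c(=O)[nH]2)cc1` sits lowest of the three numbers in a functional assay on Malme-3M cells (Homo sapiens) for inhibition (a lower number here means a stronger inhibitor of growth, a higher number a weaker inhibitor of growth), where compound 1 gives 1790 nM. Compound 2 `COc1ccc(-c2cn(-c3cccc(C(=O)/C=C/c4ccc(O)c(OC)c4)c3)c(=O)[nH]2)cc1` gives 4420 nM, and compound 3 `O=C(/C=C/c1cccc(O)c1)c1cccc(-n2cc(-c3ccccc3)[nH]c2=O)c1` gives 6210 nM. Within the data shown here, the one clean step measured, a 2.5-fold higher number from compound 1 to compound 2 (0.39 log units; beyond the scatter), concerns the chain-end aryl group, not the ring substituent. Compound 4 `COc1cc(/C=C/C(=O)c2cccc(-n3cc(-c4cc(OC)c(OC)c(OC)c4)[nH]c3=O)c2)cc(OC)c1OC` differs from compound 1 as follows: 3,4,5-trimethoxyphenyl in place of 4-methoxyphenyl on an aromatic carbon. Among the measured compounds shown here, no measured pair isolates this change, so nothing here supports a step beyond the scatter in either direction; the step of a 1.0-fold higher number from compound 1 to compound 4 (0.00 log units; within the scatter) is therefore expected to be small. Compound 4 is estimated at 1800 nM in this assay, with a range from 700 nM to 4500 nM.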

Compound 4, concentration for 50% growth inhibition: 1800 nM
The estimate for compound 4 equals the measured number at the digits printed; low and high end bracket the measured number.
By their numbers in this assay, from the lowest: compounds 1 and 4 (each within the scatter of the next); then compounds 2 and 3 (each within the scatter of the next).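

In this assay, among these compounds, a 1.0-fold higher number from compound 1 to compound 4 (0.00 log units; within the scatter) gives the first clean reading at this position, on an aromatic carbon of the five-membered aromatic ring: 3,4,5-trimethoxyphenyl is accepted in place of 4-methoxyphenyl. The earlier clean step concerned only the aryl group at the chain end, so the series now holds one step at each site. No data in hand bear on the reason for this result. Open, as far as these compounds go, is how this position responds to an aryl group carrying an amine or a carboxylic acid.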